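A few compounds are considered here, and "the series" means these few. Any claim that something is new, unique, unknown or untested is made for them only; others in the source may bear on it.

Compounds measured for cytotoxicity on prostate cancer cells:
compound 1, `COc1cc(/C=C/C(=O)c2sc(Nc3cccc(Cl)c3)nc2C)cc(OC)c1OC`: > 25000 nM
compound 2, `Cc1nc(Nc2ccccc2)sc1C(=O)/C=C/c1ccccc1`: > 25000 nM
compound 3, `COc1cc(/C=C/C(=O)c2sc(Nc3ccc(Cl)c(Cl)c3)nc2C)cc(OC)c1OC`: 19300 nM

In a functional assay on PC-3 cells (Homo sapiens) for cytotoxicity, read by MTT assay (a higher number here means a weaker inhibitor, a lower number a stronger inhibitor), compound 1 gives > 25000 nM, which is a limit of the assay and not a number. Compound 2 also gives a limit, > 25000 nM. Compound 3 gives 19300 nM. Compound 3 differs from compound 1 by chloro in place of hydrogen on an aromatic carbon, and the step of an at least 1.2-fold lower number from compound 1 to compound 3 (0.11 log units; that floor lies within the scatter) stays within the scatter; two of the three values sit at the limit of > 25000 nM in this assay, at which 2 of the 3 values shown sit. How the core of compound 2 differs from that of compound 1 is not broken down here.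

Compound 4, `Cc1nc(Nc2ccccc2)sc1C(=O)/C=C/c1ccccc1Cl`, has not yet been measured. It differs from compound 2 by chloro in place of hydrogen on an aromatic carbon. This is the same kind of change as that from compound 1 to compound 3, but not the same: there the new chloro sat ortho to a chloro group and para to a large group, here it sits ortho to a large group. Because compound 2 sits at > 25000 nM and the earlier step of an at least 1.2-fold lower number from compound 1 to compound 3 (0.11 log units; that floor lies within the scatter) was small, compound 4 is expected to stay weak in this assay. Compound 4 is expected to give 25000 nM, between 12000 nM and 60000 nM. The estimated step is a number no higher from compound 2 to compound 4 (the limit leaves the size open).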

Compound 4, half-maximal inhibitory concentration: > 25000 nM
Compound 4: no number, only a limit; the forecaster's own chance of this, stated with the estimate: 65%; the middle value lies on the limit itself.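

In this assay compound 4 gives > 25000 nM, which is a limit of the assay and not a number. Compound 2 also stands at a limit, so the step between compound 2 and compound 4 cannot be read. The compounds shown leave open what the change from phenyl to 2-chlorophenyl does to the value, with most values resting on one limit: the limit of > 25000 nM in this assay, at which 3 of the 4 values shown sit.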